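This account rests on a few compounds, and the source may have more. Where it says the series, first, only, none or still open, it means among the compounds named here.

Measured in an ADME assay on MRC5 cells (Homo sapiens) for cytotoxicity, read by neutral red uptake, with a stated time of 24 h; a higher number here means a weaker inhibitor, a lower number a stronger inhibitor:
- Compound 1 `CC(=O)Oc1c(C(C)C)cc2c3c1OC(=O)[C@@]31CCCC(C)(C)[C@@H]1CC2`: 290000 nM
- Compound 2 `CC(C)C(=O)Oc1c(C(C)C)cc2c3c1OC(=O)[C@@]31CCCC(C)(C)[C@@H]1CC2`: 119000 nM
- Compound 3 `CCCC(=O)Oc1c(C(C)C)cc2c3c1OC(=O)[C@@]31CCCC(C)(C)[C@@H]1CC2`: 44400 nM

Compound 3 has the lowest number of the three. Compound 4 `CCCCCCCCCCCCCCCC(=O)Oc1c(C(C)C)cc2c3c1OC(=O)[C@@]31CCCC(C)(C)[C@@H]1CC2` differs from it by dodecyl in place of hydrogen on a saturated chain carbon, three bonds along the chain from a carbonyl carbon. The closest guide is the one measured chain extension, a 6.5-fold lower number from compound 1 to compound 3 (0.82 log units; beyond the scatter). The change of chain shape, a 2.7-fold lower number from compound 2 to compound 3 (0.43 log units; beyond the scatter), and the other measured step, a 2.4-fold lower number from compound 1 to compound 2 (0.39 log units; beyond the scatter), were also modest and ran the same way. Another modest step to a lower number is therefore expected, though loosely, as no measured chain comes close to this length. The estimated change is a 1.8-fold lower number from compound 3 to compound 4 (0.25 log units; within the scatter). For compound 4, the estimated value is 25000 nM, within an expected range of 6000 nM to 150000 nM.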

Compound 4, half-maximal inhibitory concentration: > 1000000 nM
Compound 4: only a limit was reported (the forecaster's own chance of this, stated with the estimate: 15%); at least 40-fold (1.60 log units) between middle value and limit.
By their numbers in this assay, from the lowest: compound 3; then compound 2; then compound 1. At a limit, above all of these: compound 4.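

In this assay, within the data shown here, lengthening the chain on this carbonyl carbon does not keep lowering the number: dodecyl in place of hydrogen reverses the direction of the earlier steps, with an at least 22-fold higher number from compound 3 to compound 4 (1.35 log units; beyond the scatter). Compound 1, compound 2 and compound 3 carried only short chains, so they gave no sign of this turn. The value for compound 4 is a limit and not a number: the limit of > 1000000 nM in this assay, at which 1 of the 4 values shown sits.

Where the number turns upward between the chains of compound 3 and compound 4 stays open. So does what a hexyl chain, an octyl chain or a chain carrying an amine would give.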